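Methoxy for methyl on a benzyl ether core

This account rests on a few compounds, and the source may have more. Where it says the series, first, only, none or still open, it means among the compounds named here.

Measured compounds:
compound 1 `Cc1ccc(COc2nc3ccccc3s2)cc1` gives "not active" (no number reported)
compound 2 `Brc1cccc(COc2nc3ccccc3s2)c1` gives 51.9%
compound 3 `Cc1cc(C)cc(COc2nc3ccccc3s2)c1` gives 51.9%

In a functional assay on the whole organism with Mus musculus as the target, in the writhing test, at a dose of 100 mg/kg by the intraperitoneal route (a lower number here means less inhibition, a higher number more inhibition at the dose given (going by the name of the read-out)), compound 1 gives "not active" (no number reported), so no number stands for it; compound 2 and compound 3 each give a moderate inhibition, and those two values lie within the scatter of each other. Compound 4 `COc1ccc(COc2nc3ccccc3s2)cc1` carries the change (methoxy in place of methyl on an aromatic carbon). Among the measured compounds shown here, no measured step covers this change, so its size is unknown; the account can only note that the single carbon of compound 1 gives way to a group that brings one hydrogen-bond acceptor. Relative to compound 1, which is reported as not active, a higher number is expected for compound 4, but it may stay within the scatter or fail to register. Compound 4 is expected to give about 30%, in the range 0% to 60%.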

Compound 4, a percentage reported as inhibition, in the whole organism at one dose (the size of the read-out at that dose, not a potency): "not active" (no number reported)
The entry for compound 4 holds no number, so the estimate cannot be set against anything.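

In this assay, among the compounds shown here, compound 1 gives "not active" (no number reported) and compound 4 gives "not active" (no number reported) so no step between the two can be read. The compounds shown leave open whether methoxy in place of methyl alters inhibition at all. No supporting data bear on this result.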